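The source may report more compounds than this note shows. Statements on the series, on what has been measured and on what is new or still open speak of the compounds shown alone.

Measured so far, in an ADME assay on microsomes from liver (Homo sapiens) for pharmacokinetics; on this read-out higher numbers stand for fast clearance and lower numbers for slow clearance:
Compound 1 `CCC(=O)N1CCN(c2nc(-c3cnn(C)c3)ncc2C#N)C[C@H]1C` gives < 16 mL/min/kg, a limit of the assay rather than a number.
Compound 2 `C[C@@H]1C[C@H]1C(=O)N1CCN(c2nc(-c3cnn(C)c3)ncc2C#N)C[C@H]1C` gives < 16 mL/min/kg, likewise a limit.

Compound 2 therefore stands at the limit of < 16 mL/min/kg in this assay, at which 2 of the 2 values shown sit, and nothing more precise is known of it. Going by the values given here, the only measured step, a step that the two limits leave unreadable from compound 1 to compound 2, has no readable size, as both of its ends are limits. Compound 3 `C[C@@H]1CN(c2nc(-c3cnn(C)c3)ncc2C#N)CCN1C(=O)C1(C)CC1` differs from compound 2 by 1-methylcyclopropyl in place of 2-methylcyclopropyl on a carbonyl carbon. Among the compounds with values here, since the one step that bears on this change cannot be sized, no step beyond the scatter is expected in this assay; the expected step is a step that the limit leaves unreadable from compound 2 to compound 3. Compound 3 is estimated to give about 10 mL/min/kg, in a range from 4 mL/min/kg to 20 mL/min/kg.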

Compound 3, clearance: < 16 mL/min/kg
Compound 3 ended at the assay's limit (the forecaster's own chance of this, stated with the estimate: 75%); the middle value lies beyond the limit too.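

No step can be read among compound 1, compound 2 and compound 3, because all three sit at a limit in this assay rather than at a number: the limit of < 16 mL/min/kg in this assay, at which 3 of the 3 values shown sit.

From the compounds shown here alone, whether ethyl, 2-methylcyclopropyl and 1-methylcyclopropyl on the carbonyl carbon differ in clearance at all stays open.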